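Amide series: cyclohexylmethyl to phenyl at the carbonyl

The source may report more compounds than this note shows. Statements on the series, on what has been measured and on what is new or still open speak of the compounds shown alone.

Compound 1 `Cc1cc(C(=O)NC(C)C)nn1Cc1cc(Cl)ccc1OCc1ccccc1` gives only a limit in a physicochemical assay for lipophilicity, at pH 7.4 (a lower number here means a more polar compound, a higher number a more lipophilic compound), > 3.7. Compound 2 `Cc1cc(C(=O)Nc2ccccn2)nn1Cc1cc(Cl)ccc1OCc1ccccc1` likewise sits at a limit in this assay, > 3.7. For the measured compounds named here, compound 3 `Cc1cc(NC(=O)CC2CCCCC2)nn1Cc1cc(Cl)ccc1OCc1ccccc1` is the single compound with a number in this assay, 3.2. The values of compound 1 and compound 2 are limits, as the limit of > 3.7 in this assay, at which 2 of the 3 values shown sit, records. The measured steps are a number at least 0.50 log units lower from compound 1 to compound 3 (beyond the scatter) and a number at least 0.50 log units lower from compound 2 to compound 3 (beyond the scatter), both changes of the amide linkage rather than of the acyl substituent. Compound 4 `Cc1cc(NC(=O)c2ccccc2)nn1Cc1cc(Cl)ccc1OCc1ccccc1` differs from compound 3 by phenyl in place of cyclohexylmethyl on a carbonyl carbon. Going by the values given here, no measured step touches this position; the expectation rests on the structural change alone. The step is expected to be modest and downward, a number 0.50 log units lower from compound 3 to compound 4 (beyond the scatter), in this assay. Compound 4 is estimated at 2.7, between 2.2 and 3.3.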

Compound 4, distribution coefficient: > 3.7
Compound 4 gave a limit, no number; the forecaster's own chance of this, stated with the estimate: 10%; middle value at least 1.00 log units from the limit.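

On this position, phenyl in place of cyclohexylmethyl on a carbonyl carbon gives a number at least 0.50 log units higher from compound 3 to compound 4 (beyond the scatter) in this assay. The acyl substituent on the carbonyl carbon therefore moves the read-out on its own, and the reversed amide linkage of compound 3 and compound 4 does not by itself keep a compound off the limit. The steps from compound 1 and compound 2 to compound 4 cannot be read because both ends of each are limits: the limit of > 3.7 in this assay, at which 3 of the 4 values shown sit.

From the compounds shown here alone, the full size of the step to compound 4 stays open. Also open, going by these compounds, is where an amine or a carboxylic acid in place of phenyl on the carbonyl carbon would fall in this assay.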